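The compounds below may be only part of what the source reports. "The series", "measured", "known", "first", "only" and "open" are said of these compounds alone.

Working notes on the series, values in an ADME assay on MT4 cells (Homo sapiens) for cytotoxicity, read by MTT assay, with a stated time of 5 days; on this read-out higher numbers stand for lower toxicity in this test and lower numbers for higher toxicity in this test:

- compound 1 `N#Cc1ccc(Nc2nccc(OCc3cccnc3)n2)cc1`: 6400 nM
- compound 2 `N#Cc1ccc(Nc2nccc(OCc3cccc(Cl)c3)n2)cc1`: 153000 nM
- compound 3 `N#Cc1ccc(Nc2nccc(OCc3ccccc3F)n2)cc1`: 151000 nM

Compound 3 stands at the high end of these numbers, with a 1.0-fold lower number from compound 2 to compound 3 (0.01 log units; within the scatter) and a 24-fold higher number from compound 1 to compound 3 (1.37 log units; beyond the scatter).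

Compound 4 `N#Cc1ccc(Nc2nccc(OCc3cccc(F)c3)n2)cc1` is still to be measured. The change is 3-fluorophenyl in place of 2-fluorophenyl on a saturated chain carbon bound to an oxygen on an aromatic ring, with 3-fluorophenyl in place of 2-fluorophenyl.

The closest evidence is a 1.0-fold lower number from compound 2 to compound 3 (0.01 log units; within the scatter), a swap between two substituted phenyl groups. The large 24-fold higher number from compound 1 to compound 2 (1.38 log units; beyond the scatter) and a 24-fold higher number from compound 1 to compound 3 (1.37 log units; beyond the scatter) both start from pyridin-3-yl, which this change does not involve. No step beyond the scatter is therefore expected in this assay.

The expected step is a 1.0-fold lower number from compound 3 to compound 4 (0.00 log units; within the scatter).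

For compound 4 the estimated value is 150000 nM, with an expected range of 85000 nM to 260000 nM.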

Compound 4, half-maximal cytotoxic concentration: 105000 nM
The estimate for compound 4 lay 1.4-fold (0.15 log units) above the measured number; the measured number falls inside the stated range.
By their numbers in this assay, from the lowest: compound 1; then compounds 4, 3 and 2 (each within the scatter of the next).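

In this assay, 3-fluorophenyl in place of 2-fluorophenyl gives a 1.4-fold lower number from compound 3 to compound 4 (0.16 log units; within the scatter), so this change of fluoro placement on the phenyl ring leaves the number within the scatter. Fluoro in place of chloro gives a 1.5-fold lower number from compound 2 to compound 4 (0.16 log units; within the scatter), again within the scatter, while the step from pyridin-3-yl to 3-fluorophenyl, a 16-fold higher number from compound 1 to compound 4 (1.22 log units; beyond the scatter), extends the large gap to a third substituted phenyl group. No measurement at hand bears on the origin of these results. Still open, on these data alone, is how unsubstituted phenyl, or a phenyl carrying an amine or a carboxylic acid, would compare.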